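A Chloro Added to a Thiazole Hydrazone Series

This account rests on a few compounds, and the source may have more. Where it says the series, first, only, none or still open, it means among the compounds named here.

Three compounds share a core built from a thiazole carrying a hydrazone arm, and all were tested in a functional assay, read by spectrophotometry, with a stated time of 15 min; on this read-out lower numbers stand for stronger inhibition and higher numbers for weaker inhibition. Compound 1, with the structure `Fc1ccc(-c2csc(N/N=C/c3cccs3)n2)cc1`, gives a value of 44.1 ug/mL in this assay. Compound 2, `Clc1ccc(/C=N/Nc2nc(-c3ccccc3)cs2)c(Cl)c1`, gives 29.3 ug/mL. Compound 3, `COC(=O)c1cc(-c2csc(N/N=C/c3cccs3)n2)ccc1OCc1ccccc1`, gives 28.1 ug/mL.

Compound 2 holds the second highest of these three numbers. Its nearest neighbour is compound 3, whose number is lower by an amount that falls within the usual scatter, and its furthest neighbour is compound 1, whose number is higher but also within that scatter. The three results therefore cannot be told apart with confidence.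

Compound 4, `Clc1ccc(-c2csc(N/N=C/c3ccc(Cl)cc3Cl)n2)cc1`, has not yet been measured in this assay. It differs from compound 2 in one place: chloro in place of hydrogen on an aromatic carbon. Seen one bond further out, a phenyl becomes a 4-chlorophenyl.

For the measured compounds named here, no pair among the measured compounds shows this exact change, so there is no measured step to lean on. The change is small, and the expectation is that compound 4 stays close to compound 2, with the step of a 1.0-fold lower number from compound 2 to compound 4 (0.02 log units; within the scatter) expected to lie within the scatter rather than beyond it in either direction. On that basis compound 4 is estimated at 28 ug/mL, with a range from 13 ug/mL to 58 ug/mL.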

Compound 4, half-maximal inhibitory concentration: 32.2 ug/mL
The estimate for compound 4 lay 1.2-fold (0.06 log units) below the measured number; the range from low to high includes it.
By their numbers in this assay, from the lowest: compounds 3, 2, 4 and 1 (each within the scatter of the next).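

In this assay, for the compounds shown here, placing chloro on an aromatic carbon, para to a large group, gives a 1.1-fold higher number from compound 2 to compound 4 (0.04 log units; within the scatter), and this is the first step where only one place differs. The earlier compounds shown here differed from each other in more than one place, so none of their numbers could be tied to a single change, whereas here a phenyl and a 4-chlorophenyl can be compared directly and cannot be told apart on this read-out. This position therefore accepts the chloro with no measurable shift in the number, though nothing measured here offers an explanation for that.

On these data alone, what remains open is whether this position stays just as flat for a different kind of group, such as an amine, a carboxylic acid or a longer chain, any of which might move the number beyond the scatter. A single pair also cannot show whether the same change from hydrogen to chloro would behave alike on other compounds in the series.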